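Pyrimidinone-quinazolinone series: aryl hydroxy for chloro

The compounds below may be only part of what the source reports. "The series", "measured", "known", "first", "only" and "open" are said of these compounds alone.

Measured compounds:
compound 1, `N#Cc1c(-c2ccc(Cl)cc2)nc(SCC(=O)Nn2c(COc3ccc(Cl)cc3Cl)nc3ccccc3c2=O)[nH]c1=O`, 61.5%
compound 2, `N#Cc1c(-c2ccc(O)cc2)nc(SCC(=O)Nn2c(COc3ccc(Cl)cc3Cl)nc3ccccc3c2=O)[nH]c1=O`, 61.5%
compound 3, `O=C(CSc1nc(-c2ccc(Cl)cc2)c(C(=O)O)c(=O)[nH]1)Nn1c(COc2ccc(Cl)cc2Cl)nc2ccccc2c1=O`, 51.9%

In a functional assay on the whole organism (strain albino) for inhibition, with Rattus norvegicus as the target, read by paw edema, with stated times of 1 h and 0.5 h, at a dose of 100 mg/kg by the oral route (a lower number here means less inhibition, a higher number more inhibition at the dose given (going by the name of the read-out)), compound 1 gives 61.5%. Compound 2 differs from compound 1 by hydroxy in place of chloro on an aromatic carbon, and this change gives no change at the digits printed from compound 1 to compound 2 (within the scatter). The two cores differ by carboxy in place of cyano on an aromatic carbon; in this assay compound 3 gives 51.9%, which is a number 9.6 percentage points lower from compound 1 to compound 3 (within the scatter).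

Compound 4, `O=C(CSc1nc(-c2ccc(O)cc2)c(C(=O)O)c(=O)[nH]1)Nn1c(COc2ccc(Cl)cc2Cl)nc2ccccc2c1=O`, is not yet measured. It differs from compound 3 by hydroxy in place of chloro on an aromatic carbon, the same change as that from compound 1 to compound 2, at a place described in the same words in both pairs. For the measured compounds named here, the step is expected to be a number 0.1 percentage points higher from compound 3 to compound 4 (within the scatter), resting on the one earlier instance of this change, where compound 1 and compound 2 gave no change at the digits printed from compound 1 to compound 2 (within the scatter). Going by the values given here, with only that single pair to go on, the expectation for compound 4 is 52% in this assay, estimated to lie between 40% and 64%.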

Compound 4, a percentage reported as inhibition, in the whole organism at one dose (the size of the read-out at that dose, not a potency): 32.7%
Compound 4: middle estimate off by 19.3 percentage points, on the high side, outside the stated range (below it).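

In this assay, hydroxy in place of chloro does not carry over unchanged from the core of compound 1 to the core of compound 3, where the step is a number 19.2 percentage points lower from compound 3 to compound 4 (beyond the scatter): the same change on two cores in this assay, no change at the digits printed (within the scatter) from compound 1 to compound 2 and a number 19.2 percentage points lower (beyond the scatter) from compound 3 to compound 4, 19.2 percentage points apart, beyond the scatter of two such steps

Carboxy in place of cyano also reads differently once the aryl group is 4-hydroxyphenyl rather than 4-chlorophenyl, with a number 28.8 percentage points lower from compound 2 to compound 4 (beyond the scatter): the same change on two cores in this assay, a number 9.6 percentage points lower (within the scatter) from compound 1 to compound 3 and a number 28.8 percentage points lower (beyond the scatter) from compound 2 to compound 4, 19.2 percentage points apart, beyond the scatter of two such steps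

Within these four compounds, then, the two changes do not add up independently, but this rests on a single square of compounds at one dose and does not show a general rule for the series, nor does it give any reason for the difference.

The compounds shown leave open whether a methoxy group or an amine in place of chloro would follow compound 2 or compound 4. They also leave open whether a methyl ester in place of the carboxy group would keep the drop seen with the 4-hydroxyphenyl group.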